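Methoxy replaces a side group on a carbonyl carbon

This account rests on a few compounds, and the source may have more. Where it says the series, first, only, none or still open, it means among the compounds named here.

Compound 1 `N[C@H]1CC[C@H](Nc2c(C(=O)NCc3ccco3)nc(Br)c3cccnc23)CC1` and compound 2 `C[C@H](NC(=O)c1nc(Br)c2cccnc2c1N[C@H]1CC[C@H](N)CC1)c1ccc(F)cc1` share one core and differ only in the group on an amide-type nitrogen. In a functional assay on HEY cells (Homo sapiens) for cytotoxicity, read by MTT assay, with a stated time of 72 h (on this read-out lower numbers stand for stronger inhibition and higher numbers for weaker inhibition), compound 1 gives > 10000 nM, which is a limit of the assay and not a number. Compound 2 gives > 10000 nM, which is also a limit. Compound 2 therefore offers no exact starting number, and the whole record so far is the limit of > 10000 nM in this assay, at which 2 of the 2 values shown sit.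

Compound 3 `COC(=O)c1nc(Br)c2cccnc2c1N[C@H]1CC[C@H](N)CC1` carries methoxy in place of (1-(4-fluorophenyl)ethyl)amino on a carbonyl carbon. For the measured compounds named here, only one measured step bears on this change, and it is a step that the two limits leave unreadable from compound 1 to compound 2. That step gives no size to carry forward, and it concerns a different swap. The expectation in this assay is therefore no step beyond the usual scatter, in either direction. The estimated change is a step that the limit leaves unreadable from compound 2 to compound 3. A reading at the limit again is the likeliest outcome. For compound 3 the estimate is 12000 nM, with an expected range of 4000 nM to 30000 nM.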

Compound 3, half-maximal inhibitory concentration: > 20000 nM
Compound 3: only a limit was reported (the forecaster's own chance of this, stated with the estimate: 70%); at least 1.6-fold (0.22 log units) between middle value and limit.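

For the compounds shown here, no step among compound 1, compound 2 and compound 3 can be read in this assay, since each gives only a limit of the assay and not a number. The compounds shown leave open how strongly any of them acts in this assay, and whether the group on the carbonyl carbon changes that at all.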